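The source may report more compounds than this note shows. Statements on the series, on what has been measured and on what is new or still open speak of the compounds shown alone.

Compound 3 `CCCCCn1c(N)nc2c(OC)cccc21` gives 3740 nM in an assay on HEK293 cells for agonist activity at Toll-like receptor 8 (Homo sapiens), read by reporter gene assay; on this read-out lower numbers stand for an effect already at smaller amounts and higher numbers for an effect only at larger amounts of compound. Of the two numbers in hand it is the higher, with compound 1 `CCCCCn1c(N)nc2ccccc21` nearest at 3230 nM; the step of a 1.2-fold higher number from compound 1 to compound 3 (0.06 log units; within the scatter) keeps the pair within the scatter, so no order between them is claimed. Compound 2 `CCCCOC(=O)n1c(N)nc2ccccc21` returned "not active" (no number reported) in this assay and contributes no number.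

Compound 4 `CCCCCn1c(N)nc2c(C(F)(F)F)cccc21` follows from compound 3 by a single change, (trifluoromethyl in place of methoxy on an aromatic carbon). Among the measured compounds shown here, only one measured step touches the same aromatic carbon, a 1.2-fold higher number from compound 1 to compound 3 (0.06 log units; within the scatter), and it shows that methoxy in place of hydrogen there left the reporter read-out essentially unchanged. Nothing measured speaks to trifluoromethyl at this position, and compound 2 concerns a different part of the core, so it is not informative here. On this basis the step of a 1.1-fold lower number from compound 3 to compound 4 (0.03 log units; within the scatter) is expected to stay within the scatter, with no clear direction. Compound 4 is therefore estimated at 3500 nM, within a range from 1200 nM to 10000 nM.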

Compound 4, half-maximal effective concentration: "not active" (no number reported)
For compound 4 the study gives words and no number, so the estimate cannot be set against anything.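

In this assay, among the compounds shown here, compound 4 is reported in words only, so no step from compound 3 to compound 4 can be read. The compounds shown leave open how far trifluoromethyl in place of methoxy on this aromatic carbon separates the two. No measurement shown bears on this result.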